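Chloro for methyl on the oxadiazole aryl of compound 2

This account rests on a few compounds, and the source may have more. Where it says the series, first, only, none or still open, it means among the compounds named here.

Measured compounds:
- compound 1, `O=C1CC(c2nc(-c3cccc(Cl)c3)no2)CN1c1ccccc1Cl`: > 10000 nM
- compound 2, `Cc1ccc(N2CC(c3nc(-c4cccc(C)c4)no3)CC2=O)cc1`: 1300 nM

In an in vitro functional assay on HEK293-A cells for positive allosteric modulation of metabotropic glutamate receptor 5 (Homo sapiens), read by FLIPR and calcium flux (a lower number here means that less compound is needed, a higher number that more compound is needed for the effect), compound 1 is reported only as a limit, > 10000 nM, so it gives no number. In this assay compound 2 gives 1300 nM. Among the measured compounds shown here, of the two values shown, this is the only number, the other being the limit at which compound 1 sits (the limit of > 10000 nM in this assay, at which 1 of the 2 values shown sits). Compound 2 therefore stands as the sole numerical point of reference.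

Compound 3, `Cc1ccc(N2CC(c3nc(-c4cccc(Cl)c4)no3)CC2=O)cc1`, has not yet been measured in this assay. It differs from compound 2 in one place: chloro in place of methyl on an aromatic carbon, meta to a large group; read one bond further out, 3-methylphenyl becomes 3-chlorophenyl. For the measured compounds named here, no step between two measured compounds isolates this exchange, so there is no measured size to lean on. The expectation is a step from compound 2 to compound 3 of a 1.1-fold lower number from compound 2 to compound 3 (0.03 log units; within the scatter), which would be no more than the usual scatter in either direction. On that basis compound 3 is estimated at 1200 nM in this assay, with a range from 400 nM to 4000 nM.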

Compound 3, half-maximal effective concentration: 630 nM
Estimate against measurement, compound 3: 1.9-fold (0.28 log units) above; measured number inside the range.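

In this assay, the change from 3-methylphenyl to 3-chlorophenyl gives a 2.1-fold lower number from compound 2 to compound 3 (0.31 log units; beyond the scatter), the first measured size for this exchange, and it shows that this aromatic carbon tolerates chloro in place of methyl with a modest step toward a lower number. Among the compounds shown here, with the 3-chlorophenyl group held constant, the other end of the molecule can also be read for the first time: 4-methylphenyl in place of 2-chlorophenyl on the amide-type nitrogen in a ring gives an at least 15-fold lower number from compound 1 to compound 3 (1.20 log units; beyond the scatter), a large step that outweighs the modest one at the 3-chlorophenyl group. The size of that large step is bounded rather than exact, since it starts from a limit and not a number: the limit of > 10000 nM in this assay, at which 1 of the 3 values shown sits.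

The compounds shown leave open whether the lower number is particular to chloro at this place or would also appear with fluoro, bromo, trifluoromethyl or methoxy. They also do not separate the identity of the group on the nitrogen from its place on the ring, a question that 4-chlorophenyl or 2-methylphenyl there would address.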